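The compounds below may be only part of what the source reports. "The series", "measured", "known", "first", "only" and "open" are said of these compounds alone.

Of the compounds shown here, three of one series have been measured in a functional assay on thoracic aorta (Rattus norvegicus) for inhibition (a higher number here means that more compound is needed for the effect, a lower number that less compound is needed), and a fourth awaits its number. Compound 1 `CC1(C)CC(NC(=S)Nc2cccc(Cl)c2)c2cc(NS(C)(=O)=O)ccc2O1` carries a methanesulfonamido group and a thiourea bearing a chlorophenyl group; in this assay compound 1 gives 9800 nM. Compound 3 `CCS(=O)(=O)Nc1ccc2c(c1)C(NC(=S)Nc1cccc(Cl)c1)CC(C)(C)O2` is its (ethylsulfonyl)amino counterpart, the change being (methyl in place of hydrogen on a saturated chain carbon bound to a sulfonyl sulfur); in this assay compound 3 gives 9800 nM, so that no change at the digits printed from compound 1 to compound 3 (within the scatter). Compound 2 `CC1(C)CC(NC(=O)Nc2cccc(C#N)c2)c2cc(NS(C)(=O)=O)ccc2O1` keeps the methanesulfonamido group but has a urea bearing a cyanophenyl group in place of the thiourea; the difference between the core of compound 2 and that of compound 1 is not broken down here. In this assay compound 2 gives 9300 nM, a number that sits within the scatter of both compound 1 and compound 3, so none of the three can be set apart from the others.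

Compound 4 `CCS(=O)(=O)Nc1ccc2c(c1)C(NC(=O)Nc1cccc(C#N)c1)CC(C)(C)O2` is the unmeasured member. It differs from compound 2 by methyl in place of hydrogen on a saturated chain carbon bound to a sulfonyl sulfur, which is the same change that carries compound 1 into compound 3, at the same place. Because no change at the digits printed from compound 1 to compound 3 (within the scatter), the expectation for compound 4 rests on a single earlier instance of this change and on the closeness of all three measured values. A step of about no change at the digits printed from compound 2 to compound 4 (within the scatter) is therefore expected from compound 2 to compound 4 in this assay. For compound 4 the estimated value in this assay is 9300 nM, expected to lie between 5000 nM and 18000 nM.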

Compound 4, half-maximal effective concentration: 9500 nM
Compound 4: the middle estimate sits 1.0-fold (0.01 log units) below what was measured; the measured number falls inside the stated range.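

In this assay the change from methanesulfonamido to (ethylsulfonyl)amino, now read on the core carrying the urea with a cyanophenyl group, gives a 1.0-fold higher number from compound 2 to compound 4 (0.01 log units; within the scatter), and it agrees with the earlier instance on the core carrying the thiourea with a chlorophenyl group: the same change on two cores in this assay, no change at the digits printed (within the scatter) from compound 1 to compound 3 and a 1.0-fold higher number (0.01 log units; within the scatter) from compound 2 to compound 4, 1.0-fold (0.01 log units) apart, within the scatter of two such steps. Within these two pairs, then, the change carries from one core to the other with no step that stands out from the scatter, and the two steps cannot be told apart. This does not show that the change is without any effect, since a small step would be hidden in the scatter, nor does it show that the same would hold on any other core, since only two cores and this one change are shown.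

The compounds shown leave open whether a longer chain on the sulfonyl sulfur, or an amine or a carboxylic acid at the end of that chain, would also leave the number where it is. They also leave open what the urea and the thiourea each contribute apart from the cyanophenyl and chlorophenyl groups, as these two differences always occur together here.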